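From methyl to trifluoromethyl on compound 1

This account rests on a few compounds, and the source may have more. Where it says the series, first, only, none or still open, it means among the compounds named here.

In a functional assay on A549 cells (Homo sapiens) for antiproliferative activity, read by MTT assay, with a stated time of 24 h (a higher number here means a weaker inhibitor, a lower number a stronger inhibitor), compound 1 (`Cc1ccc(-c2nn(-c3ccccc3)cc2-c2nc3ccccc3n2S(=O)(=O)c2ccccc2)cc1`) gives 760 nM, the middle of three numbers. Compound 2 (`Cc1ccc(-c2nn(-c3ccccc3)cc2-c2nc3ccccc3n2S(=O)(=O)c2cc(C)ccc2C)cc1`) gives 270 nM, and compound 3 (`Cc1ccc(-c2nn(-c3ccccc3)cc2-c2nc3ccccc3n2S(=O)(=O)c2ccc(Br)cc2)cc1`) gives 1860 nM. Compound 4 (`O=S(=O)(c1ccccc1)n1c(-c2cn(-c3ccccc3)nc2-c2ccc(C(F)(F)F)cc2)nc2ccccc21`) is unmeasured and differs from compound 1 as follows: trifluoromethyl in place of methyl on an aromatic carbon. This is trifluoromethyl in place of methyl on an aromatic carbon, 4-methylphenyl to 4-(trifluoromethyl)phenyl.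

Within the data shown here, no measured step touches that group. All three lie on the group carried by the sulfonyl sulfur: a 2.8-fold lower number from compound 1 to compound 2 (0.45 log units; beyond the scatter), a 2.4-fold higher number from compound 1 to compound 3 (0.39 log units; beyond the scatter) and a 6.9-fold higher number from compound 2 to compound 3 (0.84 log units; beyond the scatter). They show only that single substitutions in this series move the number modestly, in either direction. The nearest guide, weak as it is, is the bromo change, a 2.4-fold higher number from compound 1 to compound 3 (0.39 log units; beyond the scatter), so a modest rise is expected rather than a fall. The expected step is a 1.3-fold higher number from compound 1 to compound 4 (0.12 log units; within the scatter), and a step within the scatter remains possible. For compound 4 the estimated value is 1000 nM, with an expected range of 350 nM to 2900 nM.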

Compound 4, half-maximal inhibitory concentration: 480 nM
Beside the measured number, compound 4's estimate is 2.1-fold (0.32 log units) above it, within the range that was stated.
By their numbers in this assay, from the lowest: compounds 2, 4 and 1 (each within the scatter of the next, the first and the last beyond it); then compound 3.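

In this assay, the change from 4-methylphenyl to 4-(trifluoromethyl)phenyl gives a 1.6-fold lower number from compound 1 to compound 4 (0.20 log units; within the scatter), the only step shown away from the group on the sulfonyl sulfur. Unlike the three steps at that sulfonyl group, all beyond the scatter, this one shows that a single methyl on the aromatic carbon para to a large group can give way to a trifluoromethyl of four heavy atoms without a change beyond the scatter. Nothing measured here offers an explanation for this result.

The compounds shown leave open how an amine, a carboxylic acid or a longer alkyl chain would read at this place. They also leave open whether 4-(trifluoromethyl)phenyl would give a similar result alongside the 2,5-dimethylphenyl or 4-bromophenyl group on the sulfonyl sulfur.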